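Swapping the side chain on a shared core

The compounds below may be only part of what the source reports. "The series", "measured", "known", "first", "only" and "open" are said of these compounds alone.

Three compounds sharing one core differ only in the chain attached to an aromatic nitrogen. Compound 1 `O=C1c2c[n+]([O-])c3ccccc3c2C(=O)c2c1c1ccccc1n2Cc1cn(C[C@@H](O)CO)nn1` carries a triazole with a dihydroxypropyl group, compound 2 `CN(C)CCCCn1c2c(c3ccccc31)C(=O)c1c[n+]([O-])c3ccccc3c1C2=O` a dimethylamino chain and compound 3 `O=C1c2c[n+]([O-])c3ccccc3c2C(=O)c2c1c1ccccc1n2CCCN1CCC(O)CC1` a hydroxypiperidine chain. In a functional assay on MDA-MB-231 cells (Homo sapiens) for cytotoxicity, read by MTT assay, with a stated time of 72 h (a lower number here means a stronger inhibitor, a higher number a weaker inhibitor), compound 1 gives 670 nM, compound 2 gives 350 nM and compound 3 gives 280 nM. Compound 3 has the lowest number of the three, yet the gap to compound 2 is within the scatter: a 1.3-fold lower number from compound 2 to compound 3 (0.10 log units; within the scatter). The step of a 2.4-fold lower number from compound 1 to compound 3 (0.38 log units; beyond the scatter) is modest but real, and a 1.9-fold lower number from compound 1 to compound 2 (0.28 log units; within the scatter) is within the scatter.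

Compound 4 `O=C1c2c[n+]([O-])c3ccccc3c2C(=O)c2c1c1ccccc1n2CCCCn1ccnc1` changes the chain end once more: (1H-imidazol-1-yl)methyl in place of 4-hydroxypiperidin-1-yl on a saturated chain carbon, three bonds along the chain from an aromatic nitrogen. The most relevant comparison is the step from compound 2 to compound 3, where exchanging one amine-bearing end for another moved the number hardly at all. Even the larger exchange from compound 1 to compound 3 gave only a modest step. For the measured compounds named here, an imidazole end has no measured precedent here, so the expected step is small, leaning slightly towards a higher number: a 1.5-fold higher number from compound 3 to compound 4 (0.18 log units; within the scatter). Compound 4 is therefore estimated at 420 nM in this assay, with a range from 160 nM to 1100 nM.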

Compound 4, half-maximal inhibitory concentration: 210 nM
Beside the measured number, compound 4's estimate is 2.0-fold (0.30 log units) above it; the measured number falls inside the stated range.
By their numbers in this assay, from the lowest: compounds 4, 3, 2 and 1 (each within the scatter of the next, the first and the last beyond it).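

The imidazole end, a five-membered aromatic ring with no hydrogen-bond donor, sits level in this assay with both the six-membered 4-hydroxypiperidin-1-yl end (a 1.3-fold lower number from compound 3 to compound 4 (0.12 log units; within the scatter)) and the dimethylamino end (a 1.7-fold lower number from compound 2 to compound 4 (0.22 log units; within the scatter)). Compounds 2, 3 and 4 therefore lie within the scatter of one another, even though their chain ends differ in ring type, ring size and hydrogen-bond donors, so the shape of the end group shows no clear link to the number across these three compounds. Compound 1, with its triazole chain, is the only one that stands apart: the imidazole compound gives the largest step of the set (a 3.2-fold lower number from compound 1 to compound 4 (0.50 log units; beyond the scatter)), though this is still modest, and no supporting data explain why the ends behave as they do.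

As far as these compounds go, how a shorter 2-(1H-imidazol-1-yl)ethyl chain, or a carboxylic acid at the chain end, would read stays open. From the compounds shown here alone, every number here also comes from a single cell line, so whether these ends would compare in the same way in other cells is unknown.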